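Piperidine nitrogen substituent in the shared core series

The compounds below may be only part of what the source reports. "The series", "measured", "known", "first", "only" and "open" are said of these compounds alone.

Among the compounds with values here, compound 3 `Cc1nc(S(C)(=O)=O)ccc1Oc1ncnc(OC2CCN(C(=S)OC(C)C)CC2)c1F` sits second highest of the three numbers so far in a functional assay on isolated protein for inhibition of Glucose-dependent insulinotropic receptor (Rattus norvegicus), read by HTRF and cAMP accumulation; a higher number here means that more compound is needed for the effect, a lower number that less compound is needed: compound 3 gives 1050 nM, with compound 1 `Cc1nc(S(C)(=O)=O)ccc1Oc1ncnc(OC2CCN(C(=O)OC(C)(C)C#N)CC2)c1F` nearest at 1320 nM and compound 2 `Cc1nc(S(C)(=O)=O)ccc1Oc1ncnc(OC2CCN(C(=O)OC3(C(F)(F)F)CCC3)CC2)c1F` furthest at 63.3 nM. The pair of compounds 1 and 3 lies within the scatter, a 1.3-fold lower number from compound 1 to compound 3 (0.10 log units; within the scatter). The unmeasured compound 4 `Cc1nc(S(C)(=O)=O)ccc1Oc1ncnc(OC2CCN(C(=O)c3ncc(Cl)cn3)CC2)c1F` differs from compound 3 at the same position: a group of 9 heavy atoms (5 carbon, 2 nitrogen, 1 oxygen, 1 chlorine; one six-membered aromatic ring with 2 hetero atoms) in place of a group of 6 heavy atoms (4 carbon, 1 oxygen, 1 sulfur; no ring), on an amine nitrogen in a ring.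

Within the data shown here, two measured steps bear on what a change at this amine nitrogen in a ring can do. Going a 21-fold lower number from compound 1 to compound 2 (1.32 log units; beyond the scatter) produced a large effect, and a 17-fold higher number from compound 2 to compound 3 (1.22 log units; beyond the scatter) returned the number to the level of compound 1. Among the measured compounds shown here, a group of this size on that nitrogen can therefore move the result markedly in either direction; no measured step, however, involves an aromatic ring at this position, so the direction for compound 4 is not established by these data.

On balance compound 4 is expected to give a lower number than compound 3, the step of a 3.5-fold lower number from compound 3 to compound 4 (0.54 log units; beyond the scatter), because compound 2 shows 63.3 nM is reachable from this position while compound 1 and compound 3 bracket the weaker end. The estimate for compound 4 is 300 nM, within 50 nM to 1800 nM.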

Compound 4, half-maximal effective concentration: 30.9 nM
The estimate for compound 4 lay 9.7-fold (0.99 log units) above the measured number; the measured number lies below the stated range.
By their numbers in this assay, from the lowest: compound 4; then compound 2; then compounds 3 and 1 (each within the scatter of the next).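

The first aromatic ring on this nitrogen's carbonyl group, 5-chloropyrimidin-2-yl, gives the largest step seen at this position in this assay: a 43-fold lower number from compound 1 to compound 4 (1.63 log units; beyond the scatter), and a 34-fold lower number from compound 3 to compound 4 (1.53 log units; beyond the scatter). The comparison with the best earlier compound is much smaller, a 2.0-fold lower number from compound 2 to compound 4 (0.31 log units; beyond the scatter), but it is still beyond the scatter, so compound 4 has the lowest number of the four. The result also shows that a low number at this position does not depend on an oxygen on the carbonyl carbon or on a trifluoromethyl-bearing cyclobutyl group, since an aromatic ring attached directly to the carbonyl carbon reaches the same low range.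

No measurement available here explains why this change lowers the number.

The compounds shown do not separate the effect of the chlorine from that of the ring itself, so unsubstituted pyrimidin-2-yl and 5-methylpyrimidin-2-yl would be the direct tests. From the compounds shown here alone, it is also open whether a plain phenyl ring on the carbonyl carbon, or a morpholine attached there through its nitrogen, would hold the number at this level.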